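A few compounds are considered here, and "the series" means these few. Any claim that something is new, unique, unknown or untested is made for them only; others in the source may bear on it.

In a functional assay on the whole organism with Rattus norvegicus as the target (on this read-out lower numbers stand for an effect already at smaller amounts and higher numbers for an effect only at larger amounts of compound), compound 1 (`CC(=O)Oc1c(F)cccc1C(=O)O`) gives 281 mg/kg and compound 3 (`CC(=O)Oc1ccc(-c2ccccc2)cc1C(=O)O`) gives 170 mg/kg while compound 2 (`O=C(O)c1cc(-c2ccccc2)ccc1O`) gives 54 mg/kg as the lowest of the three numbers. Compound 4 (`O=C(O)c1cc(-c2ccc(F)cc2)ccc1O`) has fluoro in place of hydrogen on an aromatic carbon of compound 2 (fluoro in place of hydrogen on an aromatic carbon) para to a large group. Among the compounds with values here, the one measured step of a 3.1-fold higher number from compound 2 to compound 3 (0.50 log units; beyond the scatter) goes with acetyl in place of hydrogen on an oxygen on an aromatic ring and so bears only indirectly on this change. Compound 1 also carries fluoro, but no measured partner isolates that group. No step beyond the scatter is therefore expected in this assay and the estimated step is a 1.2-fold lower number from compound 2 to compound 4 (0.08 log units; within the scatter) with no firm direction. Compound 4 is expected at 45 mg/kg with an estimated range from 20 mg/kg to 100 mg/kg in this read-out.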

Compound 4, dose for half-maximal effect: 14 mg/kg
Beside the measured number, compound 4's estimate is 3.2-fold (0.51 log units) above it, outside the stated range (below it).
By their numbers in this assay, from the lowest: compound 4; then compound 2; then compounds 3 and 1 (each within the scatter of the next).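

In this assay fluoro in place of hydrogen on an aromatic carbon, para to a large group, gives a 3.9-fold lower number from compound 2 to compound 4 (0.59 log units; beyond the scatter) and so shows that this position responds to a change of one heavy atom. The earlier compounds shown here could not show this, since compound 1 carries fluoro without a measured partner that isolates the group. No measured evidence accounts for the step. The compounds shown leave open whether chloro or methoxy at this position would go the same way, and whether fluoro gives a comparable step with the acetyl of compound 3 in place.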